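The source may hold more compounds than are shown below. What is called first, only, known or untested is meant among the compounds shown, and "the series" means these compounds.

Of the compounds shown here, three with a shared amide-bearing side chain have been tested in a functional assay on T-24 cells (Homo sapiens) for cytotoxicity, read by CCK-8 assay, with a stated time of 24 h; a higher number here means a weaker inhibitor, a lower number a stronger inhibitor. Compound 1 `C=C1CCC(c2csc(/C=C(\C)C(N)=O)c2)CC1` reaches only the limit of the assay, > 50000 nM. Compound 2 `C/C(=C\c1cc(-c2ccccc2)co1)C(N)=O` likewise stops at the limit, > 50000 nM. Compound 3 `C/C(=C\c1cc(-c2ccc(F)cc2)cs1)C(N)=O` also gives no number but the limit > 50000 nM, so it stands with the others at the limit of > 50000 nM in this assay, at which 3 of the 3 values shown sit, and cannot be ranked against them. Compound 4 `C/C(=C\c1cc(-c2ccc(C(F)(F)F)cc2)cs1)C(N)=O` differs from compound 3 by trifluoromethyl in place of fluoro on an aromatic carbon. Going by the values given here, with no measured step to lean on, the expected step from compound 3 to compound 4 in this assay is a number no higher from compound 3 to compound 4 (the limit leaves the size open), nothing beyond the scatter. Compound 4 is therefore estimated at 50000 nM, within 20000 nM to 120000 nM, most likely reported again as a limit.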

Compound 4, half-maximal inhibitory concentration: > 50000 nM
Compound 4 gave a limit, no number (the forecaster's own chance of this, stated with the estimate: 80%); the middle value lies on the limit itself.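

No step from compound 3 to compound 4 can be read, since both give only a limit: the limit of > 50000 nM in this assay, at which 4 of the 4 values shown sit.

The compounds shown leave open which change to the shared core, if any, would give a measured number rather than a limit.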